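The compounds below may be only part of what the source reports. "The series", "measured", "known", "first", "only" and "open" are said of these compounds alone.

Measured so far in a physicochemical assay for lipophilicity, read by LC-MS, using the shake flask method, at pH 7.4; a lower number here means a more polar compound, a higher number a more lipophilic compound:
- compound 1 `CC(C)(c1cc(Cl)cc(Cl)c1)N1CCC(COc2cc(F)c(C(=O)NS(C)(=O)=O)cc2C2CC2)CC1`: 3.9
- compound 2 `CS(=O)(=O)NC(=O)c1cc(C2CC2)c(OCC2CCN(Cc3ccc(OC(F)(F)F)cc3)CC2)cc1F`: 1.2

Of these two compounds, compound 2 has the lower number, at 1.2. The next one, compound 3 `CS(=O)(=O)NC(=O)c1cc(C2CC2)c(OCC2CCN(C(=O)c3cc(Cl)cc(Cl)c3)CC2)cc1F`, keeps the shared core and differs from compound 2 in one place: (3,5-dichlorophenyl)carbonyl in place of 4-(trifluoromethoxy)benzyl on an amine nitrogen in a ring. Within the data shown here, only one measured step bears on this change, and it involves the same amine nitrogen in a ring: a number 2.70 log units lower from compound 1 to compound 2 (beyond the scatter). That step is large and beyond the scatter, so a swap at this nitrogen can move the number a long way. Among the measured compounds shown here, it involved a different pair of groups, however, and no measured compound has a carbonyl on this nitrogen, so its size cannot simply be carried over. Compound 1, at 3.9, carries the same 3,5-dichlorophenyl ring as compound 3, which points to a rise from compound 2, though one expected to be much smaller than the measured step. The expected step is a number 0.50 log units higher from compound 2 to compound 3 (beyond the scatter). For compound 3 the estimated value is 1.7, with an expected range of 0.9 to 2.5.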

Compound 3, distribution coefficient: 0.9
Estimate against measurement, compound 3: 0.80 log units above; the range from low to high includes it.
By their numbers in this assay, from the lowest: compounds 3 and 2 (each within the scatter of the next); then compound 1.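

In this assay, putting (3,5-dichlorophenyl)carbonyl in place of 4-(trifluoromethoxy)benzyl on the amine nitrogen gives a number 0.30 log units lower from compound 2 to compound 3 (within the scatter), so at this position two groups with different rings and different links to the nitrogen cannot be told apart by this read-out. Replacing 1-(3,5-dichlorophenyl)-1-methylethyl with (3,5-dichlorophenyl)carbonyl gives a number 3.00 log units lower from compound 1 to compound 3 (beyond the scatter), and here the 3,5-dichlorophenyl ring is present on both sides of the step, so that ring alone does not fix the number, and what joins it to the nitrogen counts for a great deal in this pair. Nothing available here explains either step.

The compounds shown leave open where a 3,5-dichlorobenzyl group would fall on this nitrogen, since it carries the same ring with neither the carbonyl nor the branched carbon, and it could show whether the number stays close to that of compound 2 or moves towards that of compound 1. They also leave open whether a sulfonyl link in place of the carbonyl would give a number of similar size.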